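The source may report more compounds than this note shows. Statements on the series, on what has been measured and on what is new or still open speak of the compounds shown alone.

Measured in a functional assay on Daoy cells (Homo sapiens) for cytotoxicity, read by MTT assay; on this read-out higher numbers stand for an effect only at larger amounts of compound and lower numbers for an effect already at smaller amounts:
Compound 1 `C=C1CC/C=C(\C)[C@H](OC(C)=O)[C@@H]2OC(=O)C(=C)[C@H]2C[C@H](O)[C@@]2(C)CC[C@@H]1O2`: 5.6 ug/mL
Compound 2 `C=C1C(=O)O[C@H]2C/C(C)=C/CCC(=C)[C@H]3CC[C@@](C)(O3)[C@@H](O)C[C@H]12`: 3.2 ug/mL

Compound 2, at 3.2 ug/mL, lies within the usual scatter of compound 1, so the two cannot be told apart on these numbers. Compound 3 `C=C1CC/C=C(\C)C[C@@H]2OC(=O)C(=C)[C@H]2C[C@H](O)[C@@]2(C)CC[C@@H]1O2` has the same atoms and bonds as compound 2 and differs only in configuration as drawn (the two compounds have the same atoms and bonds and differ only in configuration as drawn: 1 of 6 stereo elements differ; a stereocentre at a saturated ring carbon is drawn R in compound 2 and S in compound 3). Going by the values given here, no measured pair shows what such a change does, so the expectation is uncertain. In this assay, no step beyond the scatter is expected. The estimated step is a 1.4-fold higher number from compound 2 to compound 3 (0.15 log units; within the scatter). For compound 3 the estimate is 4.5 ug/mL, with an expected range of 1.5 ug/mL to 13 ug/mL.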

Compound 3, concentration for half-maximal effect: 5.4 ug/mL
Beside the measured number, compound 3's estimate is 1.2-fold (0.08 log units) below it; the measured number falls inside the stated range.
By their numbers in this assay, from the lowest: compounds 2, 3 and 1 (each within the scatter of the next).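

In this assay, redrawing one stereocentre at a saturated ring carbon gives a 1.7-fold higher number from compound 2 to compound 3 (0.23 log units; within the scatter), so on these numbers this assay does not separate the two configurations. Nothing else changes in this comparison: the fact that compounds 2 and 3 differ only in the configuration as drawn. Hydrogen in place of acetoxy on a saturated ring carbon gives a 1.0-fold lower number from compound 1 to compound 3 (0.02 log units; within the scatter), so that exchange also stays within the scatter.

From the compounds shown here alone, what an amine or a longer ester chain on that carbon would do remains open. So does whether redrawing any of the other stereocentres would move the number.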